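The source may report more compounds than this note shows. Statements on the series, on what has been measured and on what is new or still open speak of the compounds shown alone.

Compound 1 `COc1ccccc1C(=O)Nc1ccc(Sc2nc3ccccc3s2)cc1`: > 100000 nM
Compound 2 `O=C(Nc1ccc(Sc2nc3ccccc3s2)cc1)c1ccccc1O`: > 100000 nM
Compound 3 `O=C(Nc1ccc(Sc2nc3ccccc3s2)c(Cl)c1)c1cc(Br)ccc1O`: > 100000 nM

Within the data shown here, in an assay on isolated protein for inhibition of thiosulfate sulfurtransferase (Homo sapiens), with a stated time of 60 min, in the absence of a further agent (on this read-out higher numbers stand for weaker inhibition and lower numbers for stronger inhibition), nothing measured so far is a number. Compound 1 sits at a limit of the assay, > 100000 nM. Compound 2 also sits at a limit, > 100000 nM. Compound 3 likewise sits at a limit, > 100000 nM. Among the measured compounds shown here, the one pair differing in a single place, compound 1 against compound 2, gives a step that the two limits leave unreadable from compound 1 to compound 2, so the replacement of methyl by hydrogen on the aromatic oxygen cannot be sized. Where compound 3 stands is therefore fixed only by the limit of > 100000 nM in this assay, at which 3 of the 3 values shown sit; it is neither separated from nor ordered against the other two.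

Compound 4 `O=C(Nc1ccc(Sc2nc3ccccc3s2)cc1)c1cc(Br)ccc1O` is the next member. It differs from compound 3 by hydrogen in place of chloro on an aromatic carbon, ortho to a large group and meta to a large group. For the measured compounds named here, no measured step touches a chloro, and the only measured step is unreadable, so nothing here argues for a readable move in this assay. The expected step is a number no higher from compound 3 to compound 4 (the limit leaves the size open), that is, none beyond the scatter, with the limit the most likely outcome again. For compound 4 the estimated value is 100000 nM, with a range from 30000 nM to 300000 nM.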

Compound 4, half-maximal inhibitory concentration: > 100000 nM
Compound 4: only a limit was reported (the forecaster's own chance of this, stated with the estimate: 85%); the middle value sits exactly at the limit.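

In this assay compound 4 gives > 100000 nM which is a limit of the assay and not a number, so its steps from compound 1, compound 2 and compound 3 cannot be read. The compounds shown leave open whether any change on the shared core gives a readable number on this read-out.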